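The source may report more compounds than this note shows. Statements on the series, on what has been measured and on what is new or still open speak of the compounds shown alone.

In a functional assay on CRL2813 cells (Homo sapiens) for cytotoxicity, read by sulforhodamine B assay, with a stated time of 5 days (on this read-out lower numbers stand for stronger inhibition and higher numbers for weaker inhibition), the measured compounds gave these numbers:

compound 1, `O=C(Nc1cccc(F)c1)N[C@H]1CC[C@H](Oc2ccc(F)cc2)CC1`: 8300 nM
compound 2, `O=C(Nc1ccccc1Br)N[C@H]1CC[C@H](Oc2ccc(F)cc2)CC1`: 7700 nM
compound 3, `O=C(Nc1cccc(Br)c1)N[C@H]1CC[C@H](Oc2ccc(F)cc2)CC1`: 6200 nM

Compound 3 has the lowest of the three numbers, but its nearest neighbour is compound 2 with a 1.2-fold lower number from compound 2 to compound 3 (0.09 log units; within the scatter), and the furthest is compound 1 with a 1.3-fold lower number from compound 1 to compound 3 (0.13 log units; within the scatter), so the three compounds cannot be put in any order on this read-out. The remaining step, a 1.1-fold lower number from compound 1 to compound 2 (0.03 log units; within the scatter), is likewise within the scatter.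

Compound 4, `O=C(Nc1cccc(C(=O)O)c1)N[C@H]1CC[C@H](Oc2ccc(F)cc2)CC1`, differs from compound 3 as follows: carboxy in place of bromo on an aromatic carbon. Going by the values given here, no measured step bears directly on this change. The three steps recorded so far exchange bromo and fluoro or move a bromo from one position of the phenyl to another, and each of them stayed within the scatter. Among the compounds with values here, a carboxy group enters nowhere among the measured compounds, so there is no precedent within this set for the size or direction of the step.

Compound 4 is therefore estimated at 15000 nM, with a range from 5000 nM to 50000 nM. The expected step is a 2.4-fold higher number from compound 3 to compound 4 (0.38 log units; beyond the scatter), a weakening relative to compound 3, held with low confidence.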

Compound 4, half-maximal inhibitory concentration: > 20000 nM
Compound 4: no number, only a limit; the forecaster's own chance of this, stated with the estimate: 25%; middle value at least 1.3-fold (0.12 log units) from the limit.
By their numbers in this assay, from the lowest: compounds 3, 2 and 1 (each within the scatter of the next). At a limit, above all of these: compound 4.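

In this assay compound 4 carries no number, only a limit of the assay: the limit of > 20000 nM in this assay, at which 1 of the 4 values shown sits.

Even so, the change at this place, on an aromatic carbon meta to a large group, is the first in the series to reach beyond the scatter, with an at least 3.2-fold higher number from compound 3 to compound 4 (0.50 log units; beyond the scatter). The same holds against the other two compounds, with an at least 2.5-fold higher number from compound 2 to compound 4 (0.41 log units; beyond the scatter) and an at least 2.4-fold higher number from compound 1 to compound 4 (0.38 log units; beyond the scatter), each of these steps being a lower bound on the true size. Going by these compounds alone, exchanging bromo and fluoro, or moving the bromo, had stayed within the scatter, so the earlier compounds showed a phenyl that gave the same reading with either halogen, whereas 3-carboxyphenyl in place of 3-bromophenyl separates from all of them.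

The compounds shown leave open how far the step from bromo to carboxy really runs, since compound 4 has no number of its own. They also leave open whether a methyl ester, a primary amide or a hydroxymethyl group in the same place would follow carboxy or stay with the halogens, and so which feature of the carboxy group goes with the step.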